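Testing Dimethylamino Where tert-Butyl Sat

The source may hold more compounds than are shown below. What is called first, only, known or untested is meant among the compounds shown, and "the series" means these compounds.

Of the compounds shown here, three sharing one core have been measured in a functional assay on cells (Splenocyte, Mus musculus, strain BALB/c) for inhibition, read by scintillation counting and thymidine incorporation, with a stated time of 72 h; a higher number here means a weaker inhibitor, a lower number a stronger inhibitor. Compound 1, `CC(/C=N/Nc1ccc([N+](=O)[O-])cc1)=N\NC(=O)c1ccc(Cl)cc1`, carries a chloro group and gives 4200 nM. Compound 2, `CC(/C=N/Nc1ccc([N+](=O)[O-])cc1)=N\NC(=O)c1ccc(C(F)(F)F)cc1`, carries trifluoromethyl in its place; for compound 2 the result is a limit of the assay, > 12000 nM. Compound 3, `CC(/C=N/Nc1ccc([N+](=O)[O-])cc1)=N\NC(=O)c1ccc(C(C)(C)C)cc1`, carries tert-butyl there; for compound 3 too the result is only a limit, > 12000 nM. Thus compound 3 stands at the weak end of what has been measured, with no exact number, a position it shares with one other compound at the limit of > 12000 nM in this assay, at which 2 of the 3 values shown sit. The step of an at least 2.8-fold higher number from compound 1 to compound 3 (0.45 log units; beyond the scatter) was at least modest, while a step that the two limits leave unreadable from compound 2 to compound 3 cannot be read. Compound 4, `CC(/C=N/Nc1ccc([N+](=O)[O-])cc1)=N\NC(=O)c1ccc(N(C)C)cc1`, is not yet measured; it differs from compound 3 by dimethylamino in place of tert-butyl on an aromatic carbon. Among the measured compounds shown here, no measured step involves dimethylamino, so the direction is open; the only step reaching compound 3 points to weak inhibition in this region. Compound 4 is therefore expected near 9000 nM, between 2500 nM and 30000 nM, an estimated step of an at least 1.3-fold lower number from compound 3 to compound 4 (0.12 log units; that floor lies within the scatter).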

Compound 4, half-maximal inhibitory concentration: > 12000 nM
Compound 4 gave a limit, no number; the forecaster's own chance of this, stated with the estimate: 45%; middle value at least 1.3-fold (0.12 log units) from the limit.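

Putting dimethylamino in place of chloro weakens inhibition in this assay, with an at least 2.8-fold higher number from compound 1 to compound 4 (0.45 log units; beyond the scatter), so a replacement with a nitrogen and a hydrogen-bond acceptor ends up on the same weak side as the two earlier replacements without either. Compound 4 gives only a limit of the assay, not a number, and it joins the other compounds there: the limit of > 12000 nM in this assay, at which 3 of the 4 values shown sit. The steps among compound 2, compound 3 and compound 4 cannot be read, so these three groups cannot be placed in any order.

Chloro remains the only group at this position with an exact value, so it is still unknown whether fluoro or methoxy would match or improve on compound 1. Going by these compounds, the effect of a carboxylic acid or a primary amine here also remains open.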